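Extending Compound 1 with a Bis(2-hydroxyethyl)carbamoyl Group

The source may report more compounds than this note shows. Statements on the series, on what has been measured and on what is new or still open speak of the compounds shown alone.

Measured in a functional assay on MCF7 cells (Homo sapiens) for inhibition, read by MTT assay, with a stated time of 4 days; a higher number here means a weaker inhibitor, a lower number a stronger inhibitor:
- Compound 1 `COc1cc(NC(C)CCCNC(=O)NN)c2ncccc2c1` gives 16000 nM
- Compound 2 `COc1ccc(/C(=N/NC(=O)NCCCC(C)Nc2cc(OC)cc3cccnc23)c2ccccc2)cc1` gives 5000 nM
- Compound 3 `CCOC(=O)N(C)C(c1ccccc1)c1ccccc1` gives 26000 nM

Compound 1 holds the second highest of the three numbers in this assay. Its value lies within the scatter of the value of compound 3, so these two cannot be told apart. Compound 2 reads lower than compound 1, and that gap lies beyond the scatter.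

The next compound to be tested is compound 4 `COc1cc(NC(C)CCCNC(=O)NNC(=O)N(CCO)CCO)c2ncccc2c1`, which keeps the core of compound 1. The change is bis(2-hydroxyethyl)carbamoyl in place of hydrogen on an amine nitrogen.

Among the measured compounds shown here, no measured pair in this small set isolates a change of this kind, so the data offer no direct guide to its size. Only compound 2, at 5000 nM, stands clearly apart from compound 1, and that gives weak support for expecting a lower number. In this assay, a small shift towards stronger inhibition is expected, with nothing clearly beyond the scatter. The expected change is a 1.6-fold lower number from compound 1 to compound 4 (0.20 log units; within the scatter). For compound 4 the estimated value is 10000 nM, with an expected range from 2500 nM to 40000 nM.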

Compound 4, half-maximal inhibitory concentration: 29000 nM
Estimate against measurement, compound 4: 2.9-fold (0.46 log units) below; measured number inside the range.
By their numbers in this assay, from the lowest: compound 2; then compounds 1, 3 and 4 (each within the scatter of the next).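

In this assay, placing bis(2-hydroxyethyl)carbamoyl in place of hydrogen on an amine nitrogen whose other neighbour is an amide-type nitrogen gives a 1.8-fold higher number from compound 1 to compound 4 (0.26 log units; within the scatter). The earlier compounds shown here held no pair that isolated any change at this place, and this step now gives a first direct reading: a group with no ring and two hydroxyethyl arms can enter here without a shift beyond the scatter, so the two compounds cannot be told apart in this assay. Nothing at hand speaks to the cause of this result, and a single step within the scatter gives no direction for this position.

From the compounds shown here alone, whether a different group on this same nitrogen, such as an acetyl, a carboxylic acid or a longer chain ending in an amine, would move the number beyond the scatter stays open. The compounds shown also leave open whether bis(2-hydroxyethyl)carbamoyl would read the same way on a compound other than compound 1, since this is the only step of its kind.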